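Replacing the indolyl group on the shared core

A few compounds are considered here, and "the series" means these few. Any claim that something is new, unique, unknown or untested is made for them only; others in the source may bear on it.

Measured so far:
compound 1 `COc1cc(-c2ccnc3cc(-c4ccc(F)cc4)nn23)cc(OC)c1OC`: 3800 nM
compound 2 `COc1cc(-c2ccnc3cc(-c4c[nH]c5ccccc45)nn23)cc(OC)c1OC`: 29 nM

Going by the values given here, in a functional assay on A549 cells (Homo sapiens) for inhibition, read by CCK-8 assay, with a stated time of 48 h (on this read-out lower numbers stand for stronger inhibition and higher numbers for weaker inhibition), compound 2 gives the lowest of the two numbers so far; its nearest neighbour is compound 1, and the gap between them is a 130-fold lower number from compound 1 to compound 2 (2.12 log units; beyond the scatter), which lies well beyond the scatter. Among the compounds with values here, the only measured step is this exchange of 4-fluorophenyl for 1H-indol-3-yl on an aromatic carbon of the shared core, which lowered the number strongly.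

Compound 3 `C=Cc1ccc(-c2cc3nccc(-c4cc(OC)c(OC)c(OC)c4)n3n2)cc1` has not yet been measured. It differs from compound 2 as follows: 4-vinylphenyl in place of 1H-indol-3-yl on an aromatic carbon. The new group is again a single carbon-only six-membered ring, as in compound 1, so the step from compound 1 to compound 2 is the one that bears on it, read in reverse. Within the data shown here, it is therefore expected that the number in this assay rises again by a large step, a 52-fold higher number from compound 2 to compound 3 (1.71 log units; beyond the scatter), although no measured pair shows whether 4-vinylphenyl behaves exactly like 4-fluorophenyl. The estimate for compound 3 in this assay is 1500 nM, with a range from 300 nM to 8000 nM.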

Compound 3, half-maximal inhibitory concentration: 1030 nM
For compound 3 the middle estimate is 1.5-fold (0.16 log units) above the measured one; the measured number falls inside the stated range.
By their numbers in this assay, from the lowest: compound 2; then compound 3; then compound 1.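

In this assay, 4-vinylphenyl on this aromatic carbon of the five-membered ring does not recover what 1H-indol-3-yl gives: the exchange is a large step, a 36-fold higher number from compound 2 to compound 3 (1.55 log units; beyond the scatter), so a second single six-membered carbon ring also sits well above compound 2. Within the two phenyl compounds the group on the ring also counts, though only modestly, with vinyl in place of fluoro giving a 3.7-fold lower number from compound 1 to compound 3 (0.57 log units; beyond the scatter), a step beyond the scatter but still leaving compound 3 far from compound 2. No measurement shown gives a reason for either step.

The exchange between compound 2 and compound 3 removes the fused five-membered ring and the hydrogen-bond donor together, so these compounds do not separate the two, and a methyl on the indole nitrogen would bear directly on that question. On these data alone, it also remains open how far the number moves with other groups in place of the vinyl or fluoro on the phenyl ring, such as an amine or a carboxylic acid.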